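Replacing the acylhydrazone arm of compound 1 with an aryl group

This account rests on a few compounds, and the source may have more. Where it says the series, first, only, none or still open, it means among the compounds named here.

The series shares one core, carried by compound 1 `N#CCC(=O)N/N=C1\C(=O)Nc2ccc(S(=O)(=O)N3CCOCC3)cc21`. In a functional assay on MCF7 cells (Homo sapiens) for cytotoxicity, read by sulforhodamine B assay, with a stated time of 24 h (a lower number here means a stronger inhibitor, a higher number a weaker inhibitor), compound 1 gives 27700 nM, the highest of the two numbers in hand, while its nearest neighbour compound 2 `O=C1Nc2ccc(S(=O)(=O)N3CCOCC3)cc2/C1=N/c1ccc(C(=O)O)cc1` gives 26700 nM in this assay; the two lie within the scatter of each other. Within the data shown here, the one step measured so far, a 1.0-fold lower number from compound 1 to compound 2 (0.02 log units; within the scatter), swaps the same arm that changes here for a substituted phenyl ring.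

Compound 3 `CC(=O)c1cccc(/N=C2\C(=O)Nc3ccc(S(=O)(=O)N4CCOCC4)cc32)c1` differs from compound 1 in one place: 3-acetylphenyl in place of ((cyanomethyl)carbonyl)amino on a double-bonded nitrogen. The step to compound 2 bears directly on it, as the same group leaves from the same double-bonded nitrogen and an aryl group enters, and that step stayed within the scatter. No step beyond the scatter is therefore expected in this assay, and the expected step is a 1.0-fold lower number from compound 1 to compound 3 (0.01 log units; within the scatter). Compound 3 is estimated at 27000 nM, within a range of 9000 nM to 80000 nM.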

Compound 3, half-maximal inhibitory concentration: 39200 nM
The estimate for compound 3 lay 1.5-fold (0.16 log units) below the measured number, within the range that was stated.
By their numbers in this assay, from the lowest: compounds 2, 1 and 3 (each within the scatter of the next).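

In this assay, a second aryl group on the double-bonded nitrogen, 3-acetylphenyl, again gives no step beyond the scatter from the ((cyanomethyl)carbonyl)amino arm, with a 1.4-fold higher number from compound 1 to compound 3 (0.15 log units; within the scatter). The new comparison is between the two aryl groups: 3-acetylphenyl in place of 4-carboxyphenyl gives a 1.5-fold higher number from compound 2 to compound 3 (0.17 log units; within the scatter), so this exchange also stays within the scatter, and all three groups tried at this position give numbers within the scatter of one another. Nothing available explains why these numbers stay so close.

Going by these compounds, whether any group on this nitrogen can produce a step beyond the scatter remains open. An aryl ring carrying an amine, or a longer alkyl chain in place of the aryl ring, would test this.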